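The source may hold more compounds than are shown below. What is called first, only, known or untested is meant among the compounds shown, and "the series" means these compounds.

The compounds measured in a functional assay on UACC-257 cells (Homo sapiens) for inhibition, read by sulforhodamine B assay, with a stated time of 48 h (on this read-out lower numbers stand for stronger inhibition of growth and higher numbers for weaker inhibition of growth), are:
compound 1 `COc1cc(-c2cc(/C=C/C(=O)c3ccc(N)cc3)[nH]n2)cc(OC)c1OC`, 1870 nM;
compound 2 `COc1ccc(-c2cc(/C=C/C(=O)c3ccc(N)cc3)[nH]n2)cc1OC`, 6460 nM;
compound 3 `COc1ccc(-c2cc(/C=C/C(=O)c3cc(OC)c(OC)c(OC)c3)[nH]n2)cc1OC`, 1790 nM.

Compound 1 sits second highest of the three numbers. Compound 3 lies within the scatter of compound 1, so no order between the two can be read. Compound 2 lies furthest from compound 1, as a 3.5-fold higher number from compound 1 to compound 2 (0.54 log units; beyond the scatter) shows, for hydrogen in place of methoxy on an aromatic carbon.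

Compound 4 `COc1cc(-c2cc(/C=C/C(=O)c3ccc(F)c(F)c3)[nH]n2)cc(OC)c1OC` has not been measured. It differs from compound 1 in one place: 3,4-difluorophenyl in place of 4-aminophenyl on a carbonyl carbon. Among the compounds with values here, no measured step changes only this ring of the shared core, so none bears on it directly. Compounds 2 and 3 do differ at this ring, though by another change; there compound 2 gives 6460 nM and compound 3 gives 1790 nM, the lower number. The expectation is therefore a step of a 1.2-fold lower number from compound 1 to compound 4 (0.10 log units; within the scatter), within the scatter, with wide uncertainty. Compound 4 is estimated at 1500 nM, with a range from 400 nM to 6000 nM.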

Compound 4, concentration for 50% growth inhibition: 1750 nM
Estimate against measurement, compound 4: 1.2-fold (0.07 log units) below, and the stated range covers the measured number.
By their numbers in this assay, from the lowest: compounds 4, 3 and 1 (each within the scatter of the next); then compound 2.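

In this assay the exchange of 4-aminophenyl for 3,4-difluorophenyl on a carbonyl carbon gives a 1.1-fold lower number from compound 1 to compound 4 (0.03 log units; within the scatter) and is the first step shown that changes only this ring of the shared core. The two groups differ in their counted hydrogen-bond donors and acceptors, yet the values do not separate the two compounds, so on this core the amine of compound 1 is not needed to reach a number of this size. Nothing shown gives a reason for this outcome.

The compounds shown leave open whether an unsubstituted phenyl or a 4-carboxyphenyl on the carbonyl carbon would also stay within the scatter of compound 1. They also leave open whether 3,4-difluorophenyl would give a similar step on the core of compound 2, which has hydrogen in place of one methoxy.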